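The compounds below may be only part of what the source reports. "The series", "measured", "known", "first", "only" and "open" are said of these compounds alone.

Measured so far in a toxicity assay on NIH3T3 cells (Mus musculus) for cytotoxicity, read by resazurin assay; a higher number here means that more compound is needed for the effect, a lower number that less compound is needed:
Compound 1 `O=C(c1ccc(NCc2cncn2Cc2ccc(-c3ccccc3)cc2)cc1-c1ccccc1)N1CCCCC1`: > 1000 nM, a limit.
Compound 2 `O=C(OC1CCCCC1)c1ccc(NCc2cncn2Cc2ccc(-c3ccccc3)cc2)cc1-c1ccccc1`: > 10000 nM, a limit.
Compound 3 `c1ccc(-c2ccc(Cn3cncc3CNc3ccc(-c4nc5ccccc5o4)c(-c4ccccc4)c3)cc2)cc1`: > 10000 nM, a limit.

Compound 3 has no number, only the limit > 10000 nM. The series offers (the limit of > 10000 nM in this assay, at which 2 of the 3 values shown sit), and otherwise (the limit of > 1000 nM in this assay, at which 1 of the 3 values shown sits).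

The next change leads to compound 4 `c1ccc(-c2ccc(Cn3cncc3CNc3ccc(-c4cc5ccccc5o4)c(-c4ccccc4)c3)cc2)cc1`: 1-benzofuran-2-yl in place of 1,3-benzoxazol-2-yl on an aromatic carbon. In words, 1-benzofuran-2-yl stands in place of 1,3-benzoxazol-2-yl on an aromatic carbon.

The measured steps at this aromatic carbon are a step that the two limits leave unreadable from compound 1 to compound 3 and a step that the two limits leave unreadable from compound 2 to compound 3. Neither has a readable size, and neither gives a direction. The step at the carbonyl carbon, a step that the two limits leave unreadable from compound 1 to compound 2, is equally unreadable. In this assay, no step beyond the scatter is therefore expected, and no direction is favoured.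

The expected step is a step that the limit leaves unreadable from compound 3 to compound 4. This expectation rests on compound 3, whose value > 10000 nM is a limit. Compound 4 is estimated at 12000 nM, with an expected range of 3000 nM to 30000 nM, and a report as a limit is the likeliest outcome.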

Compound 4, half-maximal effective concentration: > 10000 nM
Compound 4 was reported as a limit; the forecaster's own chance of this, stated with the estimate: 80%; the middle value lies beyond the limit too.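

In this assay, within the data shown here, compound 4 gives only a limit, > 10000 nM, so no step between compound 4 and compound 1, compound 2 or compound 3 can be read. The compounds shown leave open the actual values of all four and whether 1-benzofuran-2-yl in place of 1,3-benzoxazol-2-yl changes the read-out at all.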